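The source may report more compounds than this note shows. Statements on the series, on what has been measured and on what is new or still open speak of the compounds shown alone.

Of the compounds shown here, three sharing one core have been measured in a functional assay on the whole organism for positive allosteric modulation, with Mus musculus as the target; on this read-out lower numbers stand for an effect already at smaller amounts and higher numbers for an effect only at larger amounts of compound. Compound 1 (`CCC(=O)N(c1ccc(Cl)cc1)C1CCCC1N(C)C`) gives 3 mg/kg, compound 2 (`CCC(=O)N(c1ccc(F)cc1)C1CCCC1N(C)C`) gives 5 mg/kg, and compound 3 (`CCC(=O)N(c1ccc(C#N)cc1)C1CCCC1N(C)C`) gives 10 mg/kg. Compound 3 thus sits at the upper end of this small range. The steps leading to it are a 3.3-fold higher number from compound 1 to compound 3 (0.52 log units; beyond the scatter) and a 2.0-fold higher number from compound 2 to compound 3 (0.30 log units; within the scatter).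

Compound 4 (`CCC(=O)N(c1ccc(C(C)=O)cc1)C1CCCC1N(C)C`) carries acetyl in place of cyano on an aromatic carbon, para to a large group: acetyl in place of cyano on an aromatic carbon. Going by the values given here, no measured compound bears acetyl, so the only guide is the swaps at this same place, such as a 1.7-fold higher number from compound 1 to compound 2 (0.22 log units; within the scatter). These remain modest, so the expected step in this assay is a 1.3-fold lower number from compound 3 to compound 4 (0.10 log units; within the scatter), with no change beyond the scatter anticipated. Compound 4 is estimated at 8 mg/kg, with an expected range from 3 mg/kg to 25 mg/kg.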

Compound 4, dose for half-maximal effect: > 50 mg/kg
Compound 4 gave a limit, no number; the forecaster's own chance of this, stated with the estimate: 5%; middle value at least 6.2-fold (0.79 log units) away from the limit.
By their numbers in this assay, from the lowest: compounds 1, 2 and 3 (each within the scatter of the next, the first and the last beyond it). At a limit, above all of these: compound 4.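

In this assay compound 4 gives only a limit, not a number: the limit of > 50 mg/kg in this assay, at which 1 of the 4 values shown sits. At this place, para to a large group, chloro, fluoro and cyano differ by modest steps at most, whereas acetyl brings an at least 5.0-fold higher number from compound 3 to compound 4 (0.69 log units; beyond the scatter) and an at least 10-fold higher number from compound 2 to compound 4 (1.00 log units; beyond the scatter) and an at least 16-fold higher number from compound 1 to compound 4 (1.22 log units; beyond the scatter) on the same aromatic carbon. The position therefore accepts these three groups but not every small group.

From the compounds shown here alone, how far the true step reaches stays open for compound 4. Going by these compounds, it is also open whether a methoxy group, a primary amide or a methyl ester would follow acetyl or the other three groups.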